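The source may hold more compounds than are shown below. What is called first, only, known or untested is meant among the compounds shown, and "the series" means these compounds.

Compound 2 `COc1ccc(-c2nc(SCC(=O)c3sc(-c4ccccc4)nc3C)[nH]c(=O)c2C#N)cc1OC` gives the lowest number of the two values measured in a functional assay on U-87MG ATCC cells for antiproliferative activity against U-87 MG (Homo sapiens), read by MTT assay, with a stated time of 48 h (a lower number here means a stronger inhibitor, a higher number a weaker inhibitor), namely 15300 nM, while compound 1 `Cc1nc(-c2ccc(Cl)cc2)sc1C(=O)CSc1nc(-c2ccc(Cl)c(Cl)c2)c(C#N)c(=O)[nH]1` gives 83900 nM in this assay. For the measured compounds named here, compound 1 differs from compound 2 in more than one place, so no single step connects them. Compound 3 `COc1ccc(-c2nc(SCC(=O)c3sc(-c4ccc(Cl)cc4)nc3C)[nH]c(=O)c2C#N)cc1OC` has not yet been measured; it differs from compound 2 by chloro in place of hydrogen on an aromatic carbon, the phenyl becoming 4-chlorophenyl. Going by the values given here, with no comparable step on record, the change from compound 2 to compound 3 is expected to stay within the scatter, a 1.3-fold lower number from compound 2 to compound 3 (0.11 log units; within the scatter). Compound 3 is therefore estimated at 12000 nM, between 4000 nM and 40000 nM.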

Compound 3, half-maximal inhibitory concentration: 38600 nM
Beside the measured number, compound 3's estimate is 3.2-fold (0.51 log units) below it; measured number inside the range.
By their numbers in this assay, from the lowest: compound 2; then compound 3; then compound 1.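

In this assay the phenyl becoming 4-chlorophenyl, on an aromatic carbon para to a large group, gives a 2.5-fold higher number from compound 2 to compound 3 (0.40 log units; beyond the scatter) and so weakens the compound, the first single change read at this position. Compound 3 also opens a second single change, 3,4-dimethoxyphenyl in place of 3,4-dichlorophenyl, with a 2.2-fold lower number from compound 1 to compound 3 (0.34 log units; beyond the scatter) as its result. No measurement at hand accounts for either step.

On these data alone, whether a fluoro, a methoxy or an amine at the same place would also weaken the compound stays open. So does whether the chloro step would hold with other groups on the shared core.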